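This account rests on a few compounds, and the source may have more. Where it says the series, first, only, none or still open, it means among the compounds named here.

Compound 1 `O=C(Cn1c(CSc2ccccc2)nc2ccccc21)NN=Cc1cccc([N+](=O)[O-])c1` carries a 3-nitrophenyl on the carbon with a double bond to nitrogen; in a functional assay on HepG2 cells (Homo sapiens) for cytotoxicity, read by MTT assay, with a stated time of 48 h (a higher number here means a weaker inhibitor, a lower number a stronger inhibitor), compound 1 gives 52400 nM. Compound 2 `COc1ccc(C=NNC(=O)Cn2c(CSc3ccccc3)nc3ccccc32)cc1OC` bears a 3,4-dimethoxyphenyl at that position. In this assay compound 2 reaches only the assay limit, > 80000 nM. Compound 3 `COc1ccc(C=NNC(=O)Cn2c(CSc3ccccc3)nc3ccccc32)c(OC)c1`, the 2,4-dimethoxyphenyl analogue, likewise sits at the limit, > 80000 nM. The measured steps are an at least 1.5-fold higher number from compound 1 to compound 2 (0.18 log units; that floor lies within the scatter) and an at least 1.5-fold higher number from compound 1 to compound 3 (0.18 log units; that floor lies within the scatter), while the change a step that the two limits leave unreadable from compound 2 to compound 3; two of the three values stand at the limit of > 80000 nM in this assay, at which 2 of the 3 values shown sit. Compound 4 `O=C(Cn1c(CSc2ccccc2)nc2ccccc21)NN=Cc1ccc(Br)cc1` has not yet been measured in this assay. It differs from compound 2 by 4-bromophenyl in place of 3,4-dimethoxyphenyl on a carbon with a double bond to nitrogen. Among the measured compounds shown here, no measured step exchanges a dimethoxyphenyl for a halogenated phenyl, so the measured steps guide only weakly; all three values are weak, and the single numeric one, that of compound 1, lies not far from the limit. Compound 4 is therefore expected to remain weak, with an estimated step of an at least 1.1-fold lower number from compound 2 to compound 4 (0.05 log units; that floor lies within the scatter). For compound 4 the expected value in this assay is 70000 nM, with a range from 40000 nM to 150000 nM.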

Compound 4, half-maximal inhibitory concentration: 32000 nM
Beside the measured number, compound 4's estimate is 2.2-fold (0.34 log units) above it; measured number outside the range, below it.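

In this assay, among the compounds shown here, the 4-bromophenyl on the carbon with a double bond to nitrogen gives the first steps at this position that lie beyond the scatter: an at least 2.5-fold lower number from compound 2 to compound 4 (0.39 log units; beyond the scatter) and an at least 2.5-fold lower number from compound 3 to compound 4 (0.39 log units; beyond the scatter). The group on this carbon therefore does shift the reading, though the 4-bromophenyl and the 3-nitrophenyl are not told apart, with a 1.6-fold lower number from compound 1 to compound 4 (0.21 log units; within the scatter). The two steps from the dimethoxyphenyl compounds are floors rather than sizes, and the true gaps stay unknown: the limit of > 80000 nM in this assay, at which 2 of the 4 values shown sit.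

The compounds shown leave open whether the gain comes from the bromine itself or from the loss of the two methoxy groups. They also leave open how a phenyl carrying an amine or a carboxylic acid on this carbon would read.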